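Quinoline-amide series: aryl swap carried onto a second core

This account rests on a few compounds, and the source may have more. Where it says the series, first, only, none or still open, it means among the compounds named here.

Compound 1 `COc1cc2c(Oc3ccc(NC(=O)c4cc(-c5cccc(Cl)c5)nc5ccccc45)cc3F)ccnc2cc1OCCCN1CCC(C)CC1` and compound 2 `COc1ccc(-c2cc(C(=O)Nc3ccc(Oc4ccnc5cc(OCCCN6CCC(C)CC6)c(OC)cc45)c(F)c3)c3ccccc3n2)cc1` share one core and differ only in the aryl group on the quinoline: 4-methoxyphenyl in place of 3-chlorophenyl on an aromatic carbon. In a functional assay on HT-29 cells (Homo sapiens) for cytotoxicity, read by MTT assay, with a stated time of 72 h (a lower number here means a stronger inhibitor, a higher number a weaker inhibitor), compound 1 gives 100 nM, whereas compound 2 gives 1110 nM. The step is an 11-fold higher number from compound 1 to compound 2 (1.05 log units; beyond the scatter), so on this core the 3-chlorophenyl compound is the stronger inhibitor by a clear margin.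

Compound 3 `COc1cc2c(Oc3ccc(NC(=O)c4cc(-c5cccc(Cl)c5)nc5ccc(F)cc45)cc3F)ccnc2cc1OCCCN1CCCC1` sits on a second core; the difference between the two cores is not broken down here. In this assay compound 3 gives 670 nM, which leaves it a weaker inhibitor than compound 1 but within the scatter of compound 2, so no order between compound 3 and compound 2 can be claimed.

Compound 4 `COc1ccc(-c2cc(C(=O)Nc3ccc(Oc4ccnc5cc(OCCCN6CCCC6)c(OC)cc45)c(F)c3)c3cc(F)ccc3n2)cc1` is compound 3 with the same change that leads from compound 1 to compound 2: 4-methoxyphenyl in place of 3-chlorophenyl on an aromatic carbon. The place lines of the two changes agree word for word. Among the measured compounds shown here, only one instance of the change has been measured, and whether the second core carries it the same way is unknown, so the expectation is weighted toward the measured step while allowing for a smaller effect. The step from compound 3 to compound 4 in this assay is estimated at a 9.0-fold higher number from compound 3 to compound 4 (0.95 log units; beyond the scatter), resting on compound 1 and compound 2 and their step of an 11-fold higher number from compound 1 to compound 2 (1.05 log units; beyond the scatter). Compound 4 is therefore expected to give about 6000 nM in this assay, plausibly between 2000 nM and 20000 nM.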

Compound 4, half-maximal inhibitory concentration: 610 nM
Estimate against measurement, compound 4: 9.8-fold (0.99 log units) above, outside the stated range (below it).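

On the core of compound 3, 4-methoxyphenyl in place of 3-chlorophenyl gives, in this assay, a 1.1-fold lower number from compound 3 to compound 4 (0.04 log units; within the scatter), so the large loss seen on the core of compound 1 does not reappear on this second core. Set side by side, the two instances of one change disagree, and the outcome of this swap in this series depends on the core that carries it: the same change on two cores in this assay, an 11-fold higher number (1.05 log units; beyond the scatter) from compound 1 to compound 2 and a 1.1-fold lower number (0.04 log units; within the scatter) from compound 3 to compound 4, 12-fold (1.09 log units) apart, beyond the scatter of two such steps

Among the compounds shown here, this does not show which of the differences between the two cores is responsible, and with a single pair on each core it gives no general rule for either core; it shows only that the step measured on one core cannot be taken over unchanged to the other.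

Still open, from the compounds shown here alone, is how the change behaves on a core that differs from the core of compound 1 in one place only, which would tie the disagreement to a single difference. Also open, going by these compounds, is whether 4-chlorophenyl or 3-methoxyphenyl would follow the same split between the two cores, which would separate the effect of the group from the effect of where it sits on the phenyl ring.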